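The source may hold more compounds than are shown below. What is called first, only, known or untested is meant among the compounds shown, and "the series" means these compounds.

Compound 1 `Nc1ccc(-c2cc(=O)c3c(N)c(F)c(O)c(F)c3o2)cc1F` was tested in a functional assay on HeLa cells (Homo sapiens) for cytotoxicity, read by neutral red uptake, with a stated time of 3 days; on this read-out lower numbers stand for stronger inhibition and higher numbers for weaker inhibition; the value reported for compound 1, > 100000 nM, is a limit of the assay and not a number. Compound 2 `CN(C)c1c(F)c(N)c2c(=O)cc(-c3ccc(N)c(F)c3)oc2c1F` likewise gives a limit in this assay, > 100000 nM. Within the data shown here, compound 3 `CN(C)CC(=O)OCc1c(F)c(N)c2c(=O)cc(-c3ccc(N)c(F)c3)oc2c1F` is the one member of the set with a measured number: in this assay compound 3 gives 9200 nM. The step from compound 1 to compound 2 is a step that the two limits leave unreadable from compound 1 to compound 2. Among the measured compounds shown here, the steps of an at least 10-fold lower number from compound 1 to compound 3 (1.03 log units; beyond the scatter) and an at least 10-fold lower number from compound 2 to compound 3 (1.03 log units; beyond the scatter) are both large, and both place compound 3 as the only compound of the three with a reading inside the range of this assay, the other two sitting at the limit of > 100000 nM in this assay, at which 2 of the 3 values shown sit.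

Compound 4 `CCCCCCOCc1c(F)c(N)c2c(=O)cc(-c3ccc(N)c(F)c3)oc2c1F` differs from compound 3 in one place: hexyl in place of ((dimethylamino)methyl)carbonyl on an oxygen on a saturated carbon. For the measured compounds named here, no measured step changes this part of the side chain; the steps from compound 1 and from compound 2 to compound 3 install the whole ((((dimethylamino)methyl)carbonyl)oxy)methyl group and so bear on the change only in showing that a substituent at this carbon can move the number off the limit. The step of a 2.2-fold higher number from compound 3 to compound 4 (0.34 log units; beyond the scatter) is therefore an estimate with wide uncertainty, and compound 4 is expected to give about 20000 nM in this assay, in the range 3000 nM to 100000 nM.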

Compound 4, half-maximal inhibitory concentration: > 100000 nM
Compound 4 gave a limit, no number; the forecaster's own chance of this, stated with the estimate: 30%; middle value at least 5.0-fold (0.69 log units) away from the limit.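

In this assay, hexyl in place of ((dimethylamino)methyl)carbonyl on this oxygen gives an at least 10-fold higher number from compound 3 to compound 4 (1.03 log units; beyond the scatter), so the measurable reading of compound 3 is lost with this single change. The earlier compounds shown here showed only that the whole ((((dimethylamino)methyl)carbonyl)oxy)methyl group at this carbon could bring the number off the limit; compound 4 shows that a substituent on this carbon is not enough in itself, and that (hexyloxy)methyl, with a chain of carbon only and no nitrogen, carbonyl or hydrogen-bond acceptor in the part that changed, does not do the same. Compound 4 gives a limit and not a number, its steps from compound 1 and from compound 2 join two limits and cannot be read, and the set now stands mostly at the top of the range: the limit of > 100000 nM in this assay, at which 3 of the 4 values shown sit.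

The compounds shown leave open whether the amine or the ester carbonyl of the group in compound 3 goes with the reading. An acetyl group on this oxygen, which keeps the carbonyl without the amine, and a 2-(dimethylamino)ethyl group, which keeps the amine without the carbonyl, would separate the two.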